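The source may hold more compounds than are shown below. What is called first, only, known or untested is meant among the compounds shown, and "the series" means these compounds.

Three compounds share one core. Compound 1 `Oc1ccccc1CNc1ccc(F)cc1` and compound 2 `Oc1ccccc1CNc1ccc(N2CCCC2)cc1` each carry a small single group on that core. In a functional assay on Jurkat cells (Homo sapiens) for activation, with a stated time of 24 h (a higher number here means that more compound is needed for the effect, a lower number that less compound is needed), compound 1 is reported as "not active" (no number reported). In this assay compound 2 is likewise reported as "not active" (no number reported). Compound 3 `Cc1ccc(-c2ccc(NCc3ccccc3O)cc2)cc1` carries instead a second six-membered aromatic ring that bears a methyl group, and in this assay compound 3 gives 3790 nM. Compound 3 therefore stands alone: it is the only one of the three with a measured number, while the other two yielded no value at all.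

Compound 4 `N#Cc1ccc(-c2ccc(NCc3ccccc3O)cc2)cc1` differs from compound 3 in one place: cyano in place of methyl on an aromatic carbon. Among the measured compounds shown here, no pair of measured compounds differs in this way, so there is no measured step to lean on, and the exchange is small in size. Compound 4 is expected to give about 4000 nM, with a range from 1300 nM to 12000 nM. The expected step is a 1.1-fold higher number from compound 3 to compound 4 (0.02 log units; within the scatter), meaning no change beyond the usual scatter is expected.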

Compound 4, half-maximal effective concentration: "not active" (no number reported)
For compound 4 the study gives words and no number, so the estimate cannot be set against anything.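

Among the compounds shown here, compound 4 is reported in words only, so no step from compound 3 to compound 4 can be read. No evidence shown here bears on this result. The compounds shown leave open which other groups in place of the methyl of compound 3 would give a measured number.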